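This account rests on a few compounds, and the source may have more. Where it says the series, first, only, none or still open, it means among the compounds named here.

Of the compounds shown here, three sharing one core have been measured in a functional assay on HCT-8 cells (Homo sapiens) for cytotoxicity; a higher number here means that more compound is needed for the effect, a lower number that less compound is needed. Compound 1 `CS(=O)(=O)Oc1cc(-c2ccccc2)nc2ccccc12` carries a methylsulfonyl on an oxygen on an aromatic ring, and in this assay compound 1 gives 5.6 ug/mL. Compound 2 `CC(C)Oc1cc(-c2ccccc2)nc2ccccc12` has isopropyl in place of methylsulfonyl, and compound 2 gives 10 ug/mL; that is a 1.8-fold higher number from compound 1 to compound 2 (0.25 log units; within the scatter). Compound 3 `c1ccc(COc2cc(-c3ccccc3)nc3ccccc23)cc1` has benzyl in that place. For compound 3 the assay reports only a limit, > 10 ug/mL (the limit of > 10 ug/mL in this assay, at which 1 of the 3 values shown sits). The step of an at least 1.7-fold higher number from compound 1 to compound 3 (0.25 log units; that floor lies within the scatter) and the step of a number no lower from compound 2 to compound 3 (the limit leaves the size open) are therefore open-ended.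

Compound 4 `CCCOc1cc(-c2ccccc2)nc2ccccc12` is not yet measured. The change from compound 3 is ethyl in place of phenyl on a saturated chain carbon bound to an oxygen on an aromatic ring, so benzyloxy becomes propoxy. Going by the values given here, no measured step covers exactly this change. The closest guide is compound 2, whose isopropyl also sits on the oxygen and whose value is 10 ug/mL. The measured steps among compounds 1, 2 and 3 all lie within the scatter or are open-ended, so no shift beyond the scatter is expected. The expected step is a number no higher from compound 3 to compound 4 (the limit leaves the size open). Compound 4 is expected to give about 10 ug/mL, between 5 ug/mL and 20 ug/mL, with a real chance that the assay again reports only a limit.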

Compound 4, half-maximal effective concentration: > 10 ug/mL
Compound 4: only a limit was reported (the forecaster's own chance of this, stated with the estimate: 40%); the middle value lies on the limit itself.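

With ethyl in place of phenyl on a saturated chain carbon bound to an oxygen on an aromatic ring, the reading in this assay remains a limit, so compound 3 is no longer the only compound shown that gives one, and the phenyl is not required for this outcome: the limit of > 10 ug/mL in this assay, at which 2 of the 4 values shown sit. The steps to compound 4 from compound 3 and from compound 2 cannot be read, so the data cannot rank propyl against benzyl or isopropyl on this oxygen. Going by these compounds alone, the one readable step is an at least 1.7-fold higher number from compound 1 to compound 4 (0.25 log units; that floor lies within the scatter), and with that floor inside the scatter, it does not clearly separate propyl from methylsulfonyl.

Going by these compounds, it remains open whether a shorter chain such as methyl, a longer chain such as butyl, or a chain ending in an amine or a carboxylic acid would give a true number clearly apart from compound 1 at 5.6 ug/mL. Until such a number exists, no trend along the chain on this oxygen can be drawn from the compounds shown, and propyl against isopropyl stays at a number no lower from compound 2 to compound 4 (the limit leaves the size open) with nothing further to read.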